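The source may hold more compounds than are shown below. What is called first, only, known or untested is meant among the compounds shown, and "the series" means these compounds.

Three related nucleoside analogues have been compared in an assay on COS-7 cells for inhibition of sodium/nucleoside cotransporter 2 (Homo sapiens), read by scintillation counting; on this read-out lower numbers stand for stronger inhibition and higher numbers for weaker inhibition. Compound 1 `Nc1ncnc2c1nc(NCc1ccc(-c3ccncc3)cc1)n2[C@@H]1O[C@H](CO)[C@@H](O)[C@H]1O` gives 2700 nM, compound 2 `CC(C)Oc1cc(CNc2nc3c(N)ncnc3n2[C@@H]2O[C@H](CO)[C@@H](O)[C@H]2O)ccc1-c1ccccc1` gives 10400 nM, and compound 3 `Nc1ncnc2c1nc(NCc1ccc(-c3ccccc3)cc1O)n2[C@@H]1O[C@H](CO)[C@@H](O)[C@H]1O` gives 1300 nM. Compound 3 has the lowest of the three numbers; compound 1 is nearest to it, at a gap beyond the scatter, and compound 2 is furthest, also beyond the scatter. Compound 4 `CCOc1cc(-c2ccccc2)ccc1CNc1nc2c(N)ncnc2n1[C@@H]1O[C@H](CO)[C@@H](O)[C@H]1O` is derived from compound 3 by one change: ethyl in place of hydrogen on an oxygen on an aromatic ring. Among the measured compounds shown here, no measured pair shows this exact step. Compound 2, which also carries an alkoxy group, gives the weakest number, so a modest step towards weaker inhibition is expected, a 2.3-fold higher number from compound 3 to compound 4 (0.36 log units; beyond the scatter). Compound 4 is therefore estimated at 3000 nM, with a range from 1000 nM to 10000 nM.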

Compound 4, half-maximal inhibitory concentration: 5400 nM
Estimate against measurement, compound 4: 1.8-fold (0.26 log units) below; low and high end bracket the measured number.
By their numbers in this assay, from the lowest: compound 3; then compounds 1, 4 and 2 (each within the scatter of the next, the first and the last beyond it).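

In this assay, going from hydroxy to ethoxy on this oxygen on an aromatic ring brings a 4.2-fold higher number from compound 3 to compound 4 (0.62 log units; beyond the scatter). Among the compounds shown here, this is the only step that isolates this position, and it shows that ethyl on the oxygen gives weaker inhibition than hydrogen does, a loss the earlier compounds could not separate from other differences. No available evidence accounts for this step.

From the compounds shown here alone, it remains open whether the hydrogen's loss or the ethyl's presence drives the step. Going by these compounds, how a methyl group, a longer chain or an amine at this place would read also remains open.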